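Chloro in Place of Amino, Measured Only as Limits

The source may report more compounds than this note shows. Statements on the series, on what has been measured and on what is new or still open speak of the compounds shown alone.

Compound 1, `Nc1ncnc2c1ncn2[C@@H]1C[C@@H]2COC[C@H]2[C@H]1CO`, in an ADME assay on L1210/0 cells (Mus musculus) for cytotoxicity, with a stated time of 48 h (a higher number here means a weaker inhibitor, a lower number a stronger inhibitor), gives > 200000 nM, a limit of the assay rather than a number.
Compound 2, `OC[C@@H]1[C@@H]2COC[C@H]2C[C@H]1n1cnc2c(Cl)ncnc21`, gives > 200000 nM in this assay, again a limit.
Compound 3, `CC(O)Cn1cnc2c(N)nc(I)nc21`, gives > 200000 nM in this assay, also a limit.

The change from compound 1 to compound 2 is chloro in place of amino on an aromatic carbon. The step that the two limits leave unreadable from compound 1 to compound 2 cannot be sized, because of the limit of > 200000 nM in this assay, at which 3 of the 3 values shown sit. Compound 4, `CC(O)Cn1cnc2c(Cl)nc(I)nc21`, has not yet been measured; it differs from compound 3 by chloro in place of amino on an aromatic carbon. The difference between the core of compound 1 and the core of compound 3 is not broken down here. The place of the change is not identical either: in compound 3 the carbon is also meta to an iodo group (1 heavy atom), so the change is the same kind of change, not the same one. Compound 4 is expected to give a value at the limit as well, since in this assay the step that the limit leaves unreadable from compound 3 to compound 4 cannot be expected to become readable; this rests on the limit (the limit of > 200000 nM in this assay, at which 3 of the 3 values shown sit). The estimate for compound 4 is 300000 nM, between 100000 nM and 1000000 nM.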

Compound 4, half-maximal inhibitory concentration: > 200000 nM
Compound 4: a limit, no number; the forecaster's own chance of this, stated with the estimate: 85%; the middle value does not contradict the limit.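

Among these compounds, compound 3 and compound 4 both give only a limit of the assay, not a number, so no step between them can be read: the limit of > 200000 nM in this assay, at which 4 of the 4 values shown sit.

Left open is how strong any of the four compounds is in this assay, and whether chloro in place of amino on an aromatic carbon changes that strength at all.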